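This account rests on a few compounds, and the source may have more. Where it says the series, first, only, none or still open, it means among the compounds named here.

Measured so far:
compound 1 `CCOc1ccc(C(=O)/C=C/c2c(/C=C/c3ccc(OC)cc3)cc(OC)cc2OC)cc1` gives 6.4 ug/mL in a functional assay on B16-F10 cells (Mus musculus) for antiproliferative activity, read by MTT assay, with a stated time of 48 h; a lower number here means a stronger inhibitor, a higher number a weaker inhibitor
compound 2 `CCCCCCOc1ccc(C(=O)/C=C/c2c(/C=C/c3ccc(OC)cc3)cc(OC)cc2OC)cc1` gives 10.4 ug/mL
compound 3 `COc1ccc(/C=C/c2cc(OC)cc(OC)c2/C=C/C(=O)c2ccc(C(F)(F)F)cc2)cc1` gives 4.3 ug/mL

Compound 3 has the lowest number of the three: compound 1 sits close, a 1.5-fold lower number from compound 1 to compound 3 (0.17 log units; within the scatter), while compound 2 lies further off, a 2.4-fold lower number from compound 2 to compound 3 (0.38 log units; beyond the scatter). Compound 4 `COc1ccc(/C=C/c2cc(OC)cc(OC)c2/C=C/C(=O)c2cccc(OC)c2)cc1` differs from compound 3 by 3-methoxyphenyl in place of 4-(trifluoromethyl)phenyl on a carbonyl carbon. Among the measured compounds shown here, the steps that bear on this are the two in which trifluoromethyl replaced ethoxy or hexyloxy: the first stayed within the scatter, the second was modest. For the measured compounds named here, compound 4 returns an oxygen substituent to that ring, though as 3-methoxyphenyl, which no measured compound carries, so in this assay compound 4 is expected to shift only slightly toward a higher number, a 1.4-fold higher number from compound 3 to compound 4 (0.14 log units; within the scatter). The estimate for compound 4 is 6 ug/mL, with a range from 3 ug/mL to 12 ug/mL.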

Compound 4, half-maximal inhibitory concentration: 4.3 ug/mL
Beside the measured number, compound 4's estimate is 1.4-fold (0.14 log units) above it, within the range that was stated.
By their numbers in this assay, from the lowest: compounds 3, 4, 1 and 2 (each within the scatter of the next, the first and the last beyond it).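

Replacing 4-(trifluoromethyl)phenyl with 3-methoxyphenyl on the carbonyl carbon shows no change at the digits printed from compound 3 to compound 4 (within the scatter) in this assay, even though the entering group carries a hydrogen-bond acceptor and the leaving group carries none. Replacing 4-ethoxyphenyl at the same place gives a 1.5-fold lower number from compound 1 to compound 4 (0.17 log units; within the scatter), so these three groups cannot be told apart here, while compound 2, with its hexyloxy chain, stays beyond the scatter from compound 3. No measurement available explains this result.

As far as these compounds go, whether 4-methoxyphenyl would match 3-methoxyphenyl remains open. So does the outcome with an amine or a carboxylic acid on this ring.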